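This account rests on a few compounds, and the source may have more. Where it says the series, first, only, none or still open, it means among the compounds named here.

Of the compounds shown here, three sharing one core have been measured in a functional assay on SEM cells (Homo sapiens) for inhibition, read by MTT assay, with a stated time of 72 h; on this read-out higher numbers stand for weaker inhibition and lower numbers for stronger inhibition. Compound 1 `C=C(Br)C(=O)Nc1cccc(/C=C/C(=O)Nc2ccc(F)cc2)c1` gives 8400 nM, compound 2 `C=C(Br)C(=O)Nc1cccc(/C=C/C(=O)Nc2ccc(F)c(F)c2)c1` gives 90 nM, and compound 3 `C=C(Br)C(=O)Nc1cccc(/C=C/C(=O)Nc2ccc(Cl)cc2)c1` gives 1190 nM. Compound 3 therefore stands in the middle of the three, clearly separated from both neighbours.

Compound 4 `C=C(Br)C(=O)Nc1cccc(/C=C/C(=O)Nc2ccc(C)cc2)c1` differs from compound 3 by a single swap: methyl in place of chloro on an aromatic carbon. This puts methyl in place of chloro on an aromatic carbon, para to a large group.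

Among the measured compounds shown here, no measured compound carries methyl, so the evidence is indirect. For the measured compounds named here, the closest precedent is a swap at the same place, chloro in place of fluoro, which gave a modest change of a 7.1-fold lower number from compound 1 to compound 3 (0.85 log units; beyond the scatter). The other two steps were large: a 93-fold lower number from compound 1 to compound 2 (1.97 log units; beyond the scatter) and a 13-fold higher number from compound 2 to compound 3 (1.12 log units; beyond the scatter). Together they show that small changes to these groups can move the number well beyond the scatter. Yet neither step is a direct swap of one group for another at this place, so the modest step is the better guide.

A modest step is expected, more likely towards weaker inhibition, and the estimated change is a 2.0-fold higher number from compound 3 to compound 4 (0.30 log units; within the scatter). For compound 4 the estimated value is 2400 nM, with an expected range from 700 nM to 8000 nM.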

Compound 4, half-maximal inhibitory concentration: 190 nM
Compound 4: the middle estimate sits 13-fold (1.10 log units) above what was measured, outside the stated range (below it).
By their numbers in this assay, from the lowest: compound 2; then compound 4; then compound 3; then compound 1.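

Swapping chloro for methyl on the aromatic carbon para to a large group gives, in this assay, a 6.3-fold lower number from compound 3 to compound 4 (0.80 log units; beyond the scatter) as a clear gain in inhibition, so a change of one heavy atom for one heavy atom at this place, with no hydrogen-bond donor or acceptor entering or leaving, is enough to move the number beyond the scatter. Among the three compounds carrying a single group here, the number falls from fluoro through chloro to methyl, and the full span of that series is a 44-fold lower number from compound 1 to compound 4 (1.65 log units; beyond the scatter) as a large step, which makes the identity of this one group a strong control on the read-out. A single methyl also brings the series close to the 3,4-difluorophenyl compound without matching it, leaving a 2.1-fold higher number from compound 2 to compound 4 (0.32 log units; beyond the scatter) as a modest gap that is still beyond the scatter.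

Nothing shown here explains why methyl outperforms chloro and fluoro at this place. Open too, on these data alone, is whether the trend carries on to an ethyl, methoxy or amine group here, and whether a 3,4-dimethylphenyl group would improve on the single methyl as the second fluoro does on the single fluoro.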